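Ester Homologue of a Sub-Nanomolar Benzothiophene Anilide

The source may hold more compounds than are shown below. What is called first, only, known or untested is meant among the compounds shown, and "the series" means these compounds.

Among the measured compounds shown here, compound 1 `COC(=O)c1sc2cc(OC)ccc2c1Nc1cc(OC)c(OC)c(OC)c1` was tested in a functional assay on HT-29 cells (Homo sapiens) for cytotoxicity, read by MTT assay, with a stated time of 72 h (on this read-out higher numbers stand for weaker inhibition and lower numbers for stronger inhibition), and gave 0.9 nM, the lowest of the two numbers recorded here; the only comparison is compound 2 `COC(=O)c1sc2ccccc2c1Nc1cc(OC)c(OC)c(OC)c1`, which gave 299 nM. For the measured compounds named here, the single measured step, a 330-fold higher number from compound 1 to compound 2 (2.52 log units; beyond the scatter), comes from hydrogen in place of methoxy on an aromatic carbon, a change at a different part of the molecule from the one considered now.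

Compound 3 `CCOC(=O)c1sc2cc(OC)ccc2c1Nc1cc(OC)c(OC)c(OC)c1` differs from compound 1 by methyl in place of hydrogen on a saturated chain carbon bound to an oxygen next to a carbonyl group. Going by the values given here, no measured step touches this ester chain, so the recorded change cannot be carried over directly; the large effect in a 330-fold higher number from compound 1 to compound 2 (2.52 log units; beyond the scatter) belongs to the aromatic methoxy and says nothing about the ester. The expected outcome is therefore a step within the scatter, a 1.7-fold higher number from compound 1 to compound 3 (0.22 log units; within the scatter), with compound 3 estimated at 1.5 nM in this assay, in the range 0.4 nM to 6 nM.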

Compound 3, half-maximal inhibitory concentration: 10.2 nM
For compound 3 the middle estimate is 6.8-fold (0.83 log units) below the measured one, outside the stated range (above it).
By their numbers in this assay, from the lowest: compound 1; then compound 3; then compound 2.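

The ester chain turns out not to be a silent part of the molecule. In this assay, going from methoxycarbonyl to ethoxycarbonyl gives an 11-fold higher number from compound 1 to compound 3 (1.05 log units; beyond the scatter), so one added methyl on a saturated chain carbon bound to an oxygen next to a carbonyl group is enough to move the number well beyond the scatter. Nothing measured here explains why this small addition has so large an effect.

As far as these compounds go, two esters cannot define a trend, so it remains open whether a propyl ester or a longer chain would raise the number further, and whether a carboxylic acid or an amide in place of the ester would keep it low. From the compounds shown here alone, it is also open whether the same methyl addition would have a similar effect on compound 2.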